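Cyclopropyl in Place of Ethyl on the Saturated Ring Carbon

The source may report more compounds than this note shows. Statements on the series, on what has been measured and on what is new or still open speak of the compounds shown alone.

Compound 1 `CC[C@@H]1c2cc(Cl)ccc2C(=O)N1c1cncc2c1CCC[C@H]2NC(C)=O`: 7 nM
Compound 2 `CC1c2cc(Cl)ccc2C(=O)N1c1cccnc1`: 123 nM

In an assay on cells for inhibition of cytochrome P450 11B2, mitochondrial (Homo sapiens), read by HTRF (on this read-out higher numbers stand for weaker inhibition and lower numbers for stronger inhibition), compound 1 gives 7 nM, the lowest of the two numbers shown. Compound 2 gives 123 nM in this assay, a clearly higher number, and the gap between the two lies well beyond the usual scatter; the two compounds differ in more than one place, so the values alone are compared here.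

Compound 3 `CC(=O)N[C@@H]1CCCc2c1cncc2N1C(=O)c2ccc(Cl)cc2[C@H]1C1CC1` is the compound still to be measured. Its change from compound 1 is cyclopropyl in place of ethyl on a saturated ring carbon. Going by the values given here, no pair of measured compounds shows this kind of swap, so the expectation rests on compound 1 alone. Given how close in size the two groups are, compound 3 is expected to stay near compound 1, with the step of no change at the digits printed from compound 1 to compound 3 (within the scatter) expected to be no larger than the scatter. The estimate for compound 3 in this assay is 7 nM, with a range from 3 nM to 20 nM.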

Compound 3, half-maximal inhibitory concentration: 100 nM
Beside the measured number, compound 3's estimate is 14-fold (1.15 log units) below it; the measured number lies above the stated range.
By their numbers in this assay, from the lowest: compound 1; then compounds 3 and 2 (each within the scatter of the next).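

In this assay, cyclopropyl in place of ethyl on a saturated ring carbon gives a 14-fold higher number from compound 1 to compound 3 (1.15 log units; beyond the scatter), so this position does not treat the two groups alike, even though they differ by so little on paper. With the rest of the structure unchanged, this single swap is enough to weaken inhibition clearly, and neither group brings a hydrogen-bond donor or acceptor or a net charge. No measurement shown here explains why the swap has this effect.

On these data alone, it remains open whether the ring of the cyclopropyl group or its extra carbon matters more, and an isopropyl group or a propyl chain on this carbon could help separate the two. As far as these compounds go, how a hydroxymethyl group or an amine would fare at this carbon is also open.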